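Double-bond geometry step in an acetylated glycosyl triazole series

This account rests on a few compounds, and the source may have more. Where it says the series, first, only, none or still open, it means among the compounds named here.

Three compounds on the shared core have numbers in a functional assay on A549 cells (Homo sapiens) for cytotoxicity, read by sulforhodamine B assay, with a stated time of 48 h; a higher number here means a weaker inhibitor, a lower number a stronger inhibitor. Compound 1 `CC(=O)OC[C@H]1O[C@@H](n2cc(CN3C(=O)/C(=C/c4ccccc4)c4ccccc43)nn2)[C@H](OC(C)=O)[C@@H](OC(C)=O)[C@@H]1OC(C)=O` gives 20600 nM in this assay. Compound 2 `CC(=O)OC[C@H]1O[C@@H](n2cc(CN3C(=O)/C(=C/c4ccc(C)cc4)c4ccccc43)nn2)[C@H](OC(C)=O)[C@@H](OC(C)=O)[C@@H]1OC(C)=O` gives 16000 nM in this assay, and the step of a 1.3-fold lower number from compound 1 to compound 2 (0.11 log units; within the scatter) lies within the scatter. Compound 3 `CC(=O)OC[C@H]1O[C@@H](n2cc(CN3C(=O)/C(=C\c4ccc(N(C)C)cc4)c4ccccc43)nn2)[C@H](OC(C)=O)[C@@H](OC(C)=O)[C@@H]1OC(C)=O` gives 17700 nM in this assay; it stands second highest of the three numbers, nearest to compound 2 and furthest from compound 1, with both gaps within the scatter.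

Compound 4 `CC(=O)OC[C@H]1O[C@@H](n2cc(CN3C(=O)/C(=C/c4ccc(N(C)C)cc4)c4ccccc43)nn2)[C@H](OC(C)=O)[C@@H](OC(C)=O)[C@@H]1OC(C)=O` is not yet measured. The change is the two compounds have the same atoms and bonds and differ only in configuration as drawn: 1 of 6 stereo elements differ; a double bond is drawn Z in compound 3 and E in compound 4: the two compounds have the same atoms and bonds and differ only in configuration as drawn, a double bond drawn Z in compound 3 and E in compound 4. Among the compounds with values here, no measured step concerns double-bond geometry; the only step, a 1.3-fold lower number from compound 1 to compound 2 (0.11 log units; within the scatter), exchanges an aromatic substituent and is itself within the scatter. The three measured numbers all sit close together, so no step beyond the scatter is expected in this assay. The expected step of a 1.0-fold lower number from compound 3 to compound 4 (0.02 log units; within the scatter) is therefore small. Compound 4 is estimated at 17000 nM, with a range from 7000 nM to 40000 nM.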

Compound 4, half-maximal inhibitory concentration: 19400 nM
Compound 4: middle estimate off by 1.1-fold (0.06 log units), on the low side; the measured number falls inside the stated range.
By their numbers in this assay, from the lowest: compounds 2, 3, 4 and 1 (each within the scatter of the next).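

The pair gives the series its first reading of double-bond geometry, and the comparison is a clean one: the fact that compounds 3 and 4 differ only in the configuration as drawn. In this assay, the change from Z to E gives a 1.1-fold higher number from compound 3 to compound 4 (0.04 log units; within the scatter), so geometry does not separate these two dimethylamino compounds. With the E geometry held, dimethylamino on the aromatic carbon also stays within the scatter, with a 1.2-fold higher number from compound 2 to compound 4 (0.08 log units; within the scatter) against methyl and a 1.1-fold lower number from compound 1 to compound 4 (0.03 log units; within the scatter) against hydrogen.

Whether the geometry step stays this small with hydrogen or methyl on the aromatic carbon remains open, as the compounds shown hold only one Z and E pair. Also open, on these data alone, is whether a carboxylic acid on the aromatic carbon, or free hydroxyl groups in place of the acetates, would move the number beyond the scatter.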